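This account rests on a few compounds, and the source may have more. Where it says the series, first, only, none or still open, it means among the compounds named here.

Compound 1, with the structure `O=C1c2ccccc2CN1c1cnc(NCc2c(F)ccc3c2CCO3)n2cnnc12`, is the most lipophilic of the three compounds examined in a physicochemical assay for lipophilicity, using the shake flask method, in phosphate buffer, measured as octanol-water partition, with a stated time of 30 min, at pH 7.4 (a lower number here means a more polar compound, a higher number a more lipophilic compound), where compound 1 gives 2.7. Compound 3, `Cc1ncccc1-c1cnc(NCc2c(F)ccc3c2CCO3)c2nn(CC#N)c(=O)n12`, stands nearest to it, as compound 3 gives 2.2, a gap beyond the scatter. Compound 2, `Cc1nc(CN(C)C)ccc1-c1cnc(NCc2c(F)ccc3c2CCO3)c2cn[nH]c(=O)c12`, lies furthest away: in this assay compound 2 gives 2, also beyond the scatter. The unmeasured compound 4, `CN(C(=O)c1ccccc1)c1cnc(NCc2c(F)ccc3c2CCO3)n2cnnc12`, differs from compound 1 by the change (a group of 10 heavy atoms (8 carbon, 1 nitrogen, 1 oxygen; one six-membered aromatic ring of carbon only) in place of a group of 10 heavy atoms (8 carbon, 1 nitrogen, 1 oxygen; one five-membered non-aromatic ring with 1 hetero atom, one six-membered aromatic ring of carbon only), on an aromatic carbon). With the count of heavy atoms, donors and acceptors unchanged, only the ring closure being given up for an open benzoyl(methyl)amino group, no step beyond the scatter is expected from this change. For compound 4 the expected value in this assay is 2.5, between 2 and 3, an estimated step of a number 0.20 log units lower from compound 1 to compound 4 (within the scatter).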

Compound 4, distribution coefficient: 2.4
Compound 4: the middle estimate sits 0.10 log units above what was measured, within the range that was stated.
By their numbers in this assay, from the lowest: compounds 2, 3, 4 and 1 (each within the scatter of the next, the first and the last beyond it).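

Among these compounds, at this aromatic carbon, replacing the group of compound 1 with the benzoyl(methyl)amino group gives the first comparison of compounds that differ in one place. In this assay this change gives a number 0.30 log units lower from compound 1 to compound 4 (within the scatter). The ring closure can therefore be given up at this position without a step beyond the scatter, while the counts of heavy atoms, donors and acceptors stay the same. Nothing available explains this result. The compounds shown leave open how a morpholine or a carboxylic acid on this aromatic carbon would read in this assay.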